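The source may report more compounds than this note shows. Statements on the series, on what has been measured and on what is new or still open speak of the compounds shown alone.

In a functional assay on MDA-MB-231 cells (Homo sapiens) for antiproliferative activity (a higher number here means a weaker inhibitor, a lower number a stronger inhibitor), compound 3 `CC1=C/C(=C\C#CCCO)C(=O)C(C)(O)C12CC2` gives 2000 nM, the highest of the two numbers obtained here. Compound 2 `CC1=C/C(=C\Cl)C(=O)C(C)(O)C12CC2` gives 300 nM, and the step of a 6.7-fold higher number from compound 2 to compound 3 (0.82 log units; beyond the scatter) came with 4-hydroxybut-1-yn-1-yl in place of chloro. Compound 1 `CC1=C/C(=C\c2cccs2)C(=O)C(C)(O)C12CC2` sits at the limit of > 10000 nM in this assay, at which 1 of the 3 values shown sits, so its value > 10000 nM is a limit, not a number. From there the steps of an at least 33-fold lower number from compound 1 to compound 2 (1.52 log units; beyond the scatter) and an at least 5.0-fold lower number from compound 1 to compound 3 (0.69 log units; beyond the scatter) both ran toward stronger inhibition when the thiophen-2-yl was exchanged. Compound 4 `C=C/C=C1\C=C(C)C2(CC2)C(C)(O)C1=O` differs from compound 3 by vinyl in place of 4-hydroxybut-1-yn-1-yl on a double-bonded chain carbon bound to a double-bonded ring carbon. Because the smaller chloro group gave the lower number in a 6.7-fold higher number from compound 2 to compound 3 (0.82 log units; beyond the scatter), compound 4 with its small vinyl is expected to move toward a lower number, by a 4.0-fold lower number from compound 3 to compound 4 (0.60 log units; beyond the scatter). Compound 4 is therefore estimated at 500 nM, between 150 nM and 1800 nM.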

Compound 4, half-maximal inhibitory concentration: 28 nM
Estimate against measurement, compound 4: 18-fold (1.25 log units) above; measured number outside the range, below it.
By their numbers in this assay, from the lowest: compound 4; then compound 2; then compound 3. At a limit, above all of these: compound 1.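

Vinyl, rather than chloro, now gives the lowest number at this position in this assay, with an 11-fold lower number from compound 2 to compound 4 (1.03 log units; beyond the scatter) and a 71-fold lower number from compound 3 to compound 4 (1.85 log units; beyond the scatter). Vinyl and 4-hydroxybut-1-yn-1-yl are both carbon chains yet lie far apart, so a carbon chain here is not in itself a drawback. The step of an at least 350-fold lower number from compound 1 to compound 4 (2.55 log units; beyond the scatter) has no upper end, as compound 1 stands at a limit, not a number: the limit of > 10000 nM in this assay, at which 1 of the 4 values shown sits.

Going by these compounds, whether the drop belongs to the double bond, the shorter chain or the missing hydroxyl stays open. An ethyl group or a plain but-1-yn-1-yl chain would help separate these.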